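Swapping a propargyl ether for a methyl triazole

The compounds below may be only part of what the source reports. "The series", "measured", "known", "first", "only" and "open" are said of these compounds alone.

Of the compounds shown here, three built on a shared core have been measured in a functional assay on RAW264.7 cells (Mus musculus) for inhibition, read by Griess assay, with stated times of 2 h and 24 h; on this read-out higher numbers stand for weaker inhibition and lower numbers for stronger inhibition. Compound 1 `COc1ccc([C@@H]2CC(=O)c3c(O)cc(OCc4cn(Cc5ccccc5C#N)nn4)cc3O2)cc1O` gives 14600 nM. Compound 2 `COc1ccc([C@@H]2CC(=O)c3c(O)cc(OCc4cn(CC5CC5)nn4)cc3O2)cc1O` gives 11900 nM, and the step of a 1.2-fold lower number from compound 1 to compound 2 (0.09 log units; within the scatter) is within the scatter. Compound 3 `C#CCOc1cc(O)c2c(c1)O[C@H](c1ccc(OC)c(O)c1)CC2=O` gives 20900 nM, and the step of a 1.8-fold higher number from compound 2 to compound 3 (0.24 log units; within the scatter) is also within the scatter, so compound 3 sits alongside compound 1 and compound 2 rather than apart from them.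

Compound 4 `COc1ccc([C@@H]2CC(=O)c3c(O)cc(OCc4cn(C)nn4)cc3O2)cc1O` differs from compound 3 in one place: 1-methyl-1H-1,2,3-triazol-4-yl in place of ethynyl on a saturated chain carbon bound to an oxygen on an aromatic ring. The step from compound 2 to compound 3 is the one that bears on this change, since it removed a triazole carrying a cyclopropylmethyl group and left only the ethynyl; compound 4 puts a triazole back, now carrying a methyl. That earlier step stayed within the scatter, and the step from compound 1 to compound 2 shows that changing the group on the triazole nitrogen also stayed within the scatter. Compound 4 is therefore expected to give a number close to compound 3, with a step of a 1.6-fold lower number from compound 3 to compound 4 (0.21 log units; within the scatter), and its estimated value in this assay is 13000 nM, ranging from 6000 nM to 28000 nM.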

Compound 4, half-maximal inhibitory concentration: 15200 nM
The estimate for compound 4 lay 1.2-fold (0.07 log units) below the measured number; measured number inside the range.
By their numbers in this assay, from the lowest: compounds 2, 1, 4 and 3 (each within the scatter of the next).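

In this assay, the ethynyl and the much larger 1-methyl-1H-1,2,3-triazol-4-yl can be compared directly, and the step is a 1.4-fold lower number from compound 3 to compound 4 (0.14 log units; within the scatter), so adding a five-membered aromatic ring with 3 hydrogen-bond acceptors at this place leaves the read-out within the scatter. The smallest group on the triazole nitrogen also fits with the larger ones, with steps of a 1.3-fold higher number from compound 2 to compound 4 (0.11 log units; within the scatter) and a 1.0-fold higher number from compound 1 to compound 4 (0.02 log units; within the scatter), so methyl, cyclopropylmethyl and 2-cyanobenzyl cannot be told apart here. Nothing available explains why these compounds read alike.

The compounds shown leave open whether an amine or a carboxylic acid on the group at the triazole nitrogen would move the number beyond the scatter. Going by these compounds, a longer chain on the oxygen on the aromatic ring also remains open.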